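The source may report more compounds than this note shows. Statements on the series, on what has been measured and on what is new or still open speak of the compounds shown alone.

Series values in a functional assay on Jurkat cells (Homo sapiens) for antiproliferative activity, read by MTT assay, with a stated time of 48 h; a lower number here means a stronger inhibitor, a higher number a weaker inhibitor:
- compound 1 `O=C(CCCCCCn1cc(Nc2ncc(Cl)c(Nc3cccc(Cl)c3)n2)cn1)NO` gives 100 nM
- compound 2 `COc1ccc(Nc2nc(Nc3cnn(CCCCCCC(=O)NO)c3)ncc2Cl)cc1` gives 130 nM
- compound 3 `O=C(CCCCCn1cc(Nc2ncc(Cl)c(Nc3cccc(Cl)c3)n2)cn1)NO` gives 50 nM

Compound 3 holds the low end of these numbers, but its separation from compound 1 is within the scatter (step a 2.0-fold lower number from compound 1 to compound 3 (0.30 log units; within the scatter)). Only compound 2 stands clearly apart from it.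

Next is compound 4 `O=C(CCCCCn1cc(Nc2ncc(Cl)c(Nc3ccc(F)cc3)n2)cn1)NO`, which carries 4-fluorophenyl in place of 3-chlorophenyl on a nitrogen on an aromatic ring.

For the measured compounds named here, the one measured step at this place is a 1.3-fold higher number from compound 1 to compound 2 (0.11 log units; within the scatter), which replaces the same 3-chlorophenyl with 4-methoxyphenyl and stays small. The chain step from compound 1 to compound 3 does not bear on this change. Going by the values given here, no compound with 4-fluorophenyl has been measured, so the precedent is indirect.

A slight rise, no larger than the scatter, is therefore expected in this assay, as the expected step of a 1.3-fold higher number from compound 3 to compound 4 (0.11 log units; within the scatter) shows.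

For compound 4 the estimated value is 65 nM (expected range 30 nM to 140 nM).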

Compound 4, half-maximal inhibitory concentration: 60 nM
Compound 4: middle estimate off by 1.1-fold (0.03 log units), on the high side; low and high end bracket the measured number.
By their numbers in this assay, from the lowest: compounds 3, 4, 1 and 2 (each within the scatter of the next, the first and the last beyond it).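

In this assay, the step of a 1.2-fold higher number from compound 3 to compound 4 (0.08 log units; within the scatter) shows that a change of the aryl group on a nitrogen on an aromatic ring stays within the scatter with the shorter hydroxycarbamoyl chain as well. Until now this place had been tested only with the longer chain, through a 1.3-fold higher number from compound 1 to compound 2 (0.11 log units; within the scatter). The data given here include no measurement that accounts for this insensitivity.

The halogen and its ring position change together in this step, so 4-chlorophenyl would be needed to read them apart. Going by these compounds, it also remains open whether this tolerance extends to cyclohexyl or to a phenyl carrying an amine or a carboxylic acid, since every group tested here at this place is a substituted phenyl.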